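This account rests on a few compounds, and the source may have more. Where it says the series, first, only, none or still open, it means among the compounds named here.

Measured so far in an ADME assay on HEK293 cells (Homo sapiens) for cytotoxicity, read by MTT assay, with a stated time of 72 h; a lower number here means a stronger inhibitor, a higher number a weaker inhibitor:

- Compound 1 `O=C(CN1CCN(C(=O)c2ccc(Cl)cc2)CC1)N1CCN(CCCc2c[nH]c3ccccc23)CC1`: 98200 nM
- Compound 2 `COc1ccc2[nH]cc(CCCN3CCN(C(=O)CN4CCN(C(=O)c5ccccc5)CC4)CC3)c2c1`: > 200000 nM

Compound 2 gives no exact number in this assay. Its entry of > 200000 nM is a limit of the assay, and (the limit of > 200000 nM in this assay, at which 1 of the 2 values shown sits). The true position of compound 2 is therefore unknown, and only the limit can serve as a reference point.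

Compound 3 `COc1ccc2[nH]cc(CCCN3CCN(C(=O)CN4CCN(C(=O)c5ccc(Cl)cc5)CC4)CC3)c2c1` has not yet been measured. It is compound 2 with a single change, (chloro in place of hydrogen on an aromatic carbon). The chloro group sits on an aromatic carbon, para to a large group, turning phenyl into 4-chlorophenyl.

Going by the values given here, no measured pair shows this change on its own, so the evidence is thin. Compound 1 also carries the 4-chlorophenyl group, and it gives 98200 nM, a true number rather than a limit. That single value points to a modest move toward a lower number, though compound 1 also differs from compound 3 elsewhere. The expected change is an estimated at least 1.8-fold lower number from compound 2 to compound 3 (0.25 log units; that floor lies within the scatter). For compound 3 the expected value is 110000 nM, with an estimated range from 50000 nM to 200000 nM.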

Compound 3, half-maximal inhibitory concentration: 117000 nM
For compound 3 the middle estimate is 1.1-fold (0.03 log units) below the measured one, and the stated range covers the measured number.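

In this assay, putting chloro on the aromatic carbon of the phenyl ring, which turns benzoyl into (4-chlorophenyl)carbonyl, gives an at least 1.7-fold lower number from compound 2 to compound 3 (0.23 log units; that floor lies within the scatter), so this change can be read only as a floor and not as a measured size. Compound 2 holds a limit and not a number: the limit of > 200000 nM in this assay, at which 1 of the 3 values shown sits. Compound 3 also links the other two compounds, which differ from each other in more than one place, and with the 4-chlorophenyl group kept, the added methoxy group gives a 1.2-fold higher number from compound 1 to compound 3 (0.08 log units; within the scatter), so on this core the methoxy group makes no difference that can be told from the scatter.

On these data alone, the true size of the chloro step stays unknown, and the floor alone cannot show whether chloro changes the reading at all. Also open, as far as these compounds go, is whether another group at this position, such as fluoro, methyl, an amine or a carboxylic acid, would give a reading close to that of the chloro compounds or a clearly different one.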